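Acetyl on the aromatic ring of compound 2

The source may report more compounds than this note shows. Statements on the series, on what has been measured and on what is new or still open speak of the compounds shown alone.

Among the measured compounds shown here, compound 2 `N#CC1CN1C(=O)Nc1ccccc1` gives the lowest of the two numbers measured so far in a functional assay on L1210 cells (Mus musculus) for inhibition, read by MTT assay (on this read-out higher numbers stand for weaker inhibition and lower numbers for stronger inhibition), namely 1200 nM. For the measured compounds named here, its only neighbour, compound 1 `CCOC(=O)c1ccc(NC(=O)N2CC2C#N)cc1`, gives 9700 nM in this assay. Going by the values given here, the single measured step, an 8.1-fold lower number from compound 1 to compound 2 (0.91 log units; beyond the scatter), pairs a carbonyl-bearing ring substituent with the higher number. Compound 3 `CC(=O)c1cccc(NC(=O)N2CC2C#N)c1` differs from compound 2 by acetyl in place of hydrogen on an aromatic carbon. That step bears only loosely on this change, since the new group sits at a different place on the ring, so a modest move toward a higher number is expected, about a 2.9-fold higher number from compound 2 to compound 3 (0.46 log units; beyond the scatter). Compound 3 is therefore estimated at 3500 nM in this assay, within 1000 nM to 14000 nM.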

Compound 3, half-maximal inhibitory concentration: 9600 nM
The estimate for compound 3 lay 2.7-fold (0.44 log units) below the measured number; measured number inside the range.
By their numbers in this assay, from the lowest: compound 2; then compounds 3 and 1 (each within the scatter of the next).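

The step of an 8.0-fold higher number from compound 2 to compound 3 (0.90 log units; beyond the scatter) in this assay shows that a ring substituent need not sit where compound 1 carries its ethoxycarbonyl to give a higher number. Acetyl, meta to a group of 8 heavy atoms, is enough on its own to produce a step beyond the scatter. No measurement shown gives a reason for this step. As far as these compounds go, whether the higher number follows from acetyl itself or from any group at this place stays open. An amine or a methyl group here, or acetyl at the ethoxycarbonyl position of compound 1, would separate these readings.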